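Swapping Pyridin-3-yl for Phenyl: An Expected Outcome

The compounds below may be only part of what the source reports. "The series", "measured", "known", "first", "only" and "open" are said of these compounds alone.

Compound 1 `CN1C(=O)C2=C(C1=O)N(CC(=O)Nc1ccc(-c3cccnc3)nc1)CCC2`: 11 nM
Compound 2 `CN1C(=O)C2=C(C1=O)N(CC(=O)Nc1ccc(-c3cccnc3)nn1)CCC2`: 29 nM

The two measured compounds share the same core and were tested in an assay on cells for inhibition of Protein-serine O-palmitoleoyltransferase porcupine (Homo sapiens), read by reporter gene assay; on this read-out higher numbers stand for weaker inhibition and lower numbers for stronger inhibition. Compound 1 gives 11 nM, the lowest of the two numbers. Compound 2 gives 29 nM, a higher number that lies beyond the usual scatter of repeated measurements, so compound 1 is the stronger inhibitor of this pair.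

Compound 3 `CN1C(=O)C2=C(C1=O)N(CC(=O)Nc1ccc(-c3ccccc3)nc1)CCC2` has not yet been measured. It differs from compound 1 in one place: phenyl in place of pyridin-3-yl on an aromatic carbon. Within the data shown here, no measured pair shows this particular change, so its effect cannot be read from the data; the only guide is that both measured compounds sit at low numbers. A small step is expected, weakening or none beyond the scatter, giving a 1.8-fold higher number from compound 1 to compound 3 (0.26 log units; within the scatter). Compound 3 is therefore estimated at 20 nM, with a range from 5 nM to 80 nM.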

Compound 3, half-maximal inhibitory concentration in the Protein-serine O-palmitoleoyltransferase porcupine assay: 6 nM
Beside the measured number, compound 3's estimate is 3.3-fold (0.52 log units) above it; the measured number falls inside the stated range.
By their numbers in the Protein-serine O-palmitoleoyltransferase porcupine assay, from the lowest: compounds 3 and 1 (each within the scatter of the next); then compound 2.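

In the Protein-serine O-palmitoleoyltransferase porcupine assay, phenyl in place of pyridin-3-yl on this aromatic carbon gives a 1.8-fold lower number from compound 1 to compound 3 (0.26 log units; within the scatter), so the two compounds cannot be told apart on inhibition. The ring nitrogen of pyridin-3-yl is therefore not needed for inhibition at this level, a point that compounds 1 and 2 alone could not settle. In a physicochemical assay for solubility, measured as thermodynamic solubility, at pH 7.4 (a higher number here means a more soluble compound, a lower number a less soluble compound), compound 1 gives 13 ug/mL and compound 3 gives 0.75 ug/mL. The same change does separate the two compounds in the physicochemical assay, so at this position the choice of ring matters for solubility rather than for inhibition: the measured solubility of compound 1, 13 ug/mL, and of compound 3, 0.75 ug/mL, a 17-fold lower number (1.24 log units; beyond the scatter)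

As far as these compounds go, it remains open whether another group here, such as a morpholine or a pyrimidin-5-yl ring, would keep inhibition while giving a higher solubility number. Also open, from the compounds shown here alone, is whether phenyl in place of pyridin-3-yl would have the same outcome on the core of compound 2.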